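Benzyloxy to Benzyl: Expected Cytotoxicity of Compound 4

The compounds below may be only part of what the source reports. "The series", "measured", "known", "first", "only" and "open" are said of these compounds alone.

Compound 1 `COc1cccc(CN2C(=O)CN(C(=O)c3cc4cc(OC)ccc4o3)C[C@@H]2CCc2ccccc2)c1`: 4500 nM
Compound 2 `COc1ccc2[nH]c(C(=O)N3CC(=O)N(Cc4ccccc4)[C@@H](CCc4ccccc4)C3)cc2c1`: > 30000 nM
Compound 3 `COc1cccc(CN2C(=O)CN(C(=O)c3cc4cc(OC)ccc4[nH]3)C[C@@H]2COCc2ccccc2)c1`: > 10000 nM

These three compounds share a common core and were tested in an ADME assay on Vero cells (Chlorocebus sabaeus) for cytotoxicity, with a stated time of 7 days; on this read-out lower numbers stand for higher toxicity in this test and higher numbers for lower toxicity in this test. Compound 1 gives 4500 nM. For compound 2 the assay reports only a limit, > 30000 nM. For compound 3 it likewise reports only a limit, > 10000 nM; this result sits at the limit of > 10000 nM in this assay, at which 1 of the 3 values shown sits, and one other value in the set sits at the limit of > 30000 nM in this assay, at which 1 of the 3 values shown sits. So compound 3 stands among the least toxic compounds shown, though with a limit rather than a number.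

Compound 4 `COc1cccc(CN2C(=O)CN(C(=O)c3cc4cc(OC)ccc4[nH]3)C[C@@H]2CCc2ccccc2)c1` has not yet been measured. It differs from compound 3 by benzyl in place of benzyloxy on a saturated chain carbon bound to a saturated ring carbon. Within the data shown here, no step between measured compounds covers exactly this change. Compound 4 does share its benzyl chain with compound 1, and in this assay compound 1 gives 4500 nM, though its core differs from that of compound 4.

A small step is expected, a step that the limit leaves unreadable from compound 3 to compound 4, at most toward slightly higher toxicity and possibly none beyond the scatter. Compound 4 is therefore expected to give about 15000 nM, within 5000 nM to 40000 nM, and quite possibly only a limit again.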

Compound 4, half-maximal cytotoxic concentration: 4500 nM
Compound 4: middle estimate off by 3.3-fold (0.52 log units), on the high side; the measured number lies below the stated range.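

In this assay, benzyl in place of benzyloxy on a saturated chain carbon bound to a saturated ring carbon gives an at least 2.2-fold lower number from compound 3 to compound 4 (0.34 log units; beyond the scatter), so this position does respond to the change, and the size given is only a minimum since compound 3 holds just a limit: the limit of > 10000 nM in this assay, at which 1 of the 4 values shown sits.
Methoxy in place of hydrogen on an aromatic carbon gives an at least 6.6-fold lower number from compound 2 to compound 4 (0.82 log units; beyond the scatter), so a second place in the molecule also moves the number, again as a minimum since compound 2 holds just a limit: the limit of > 30000 nM in this assay, at which 1 of the 4 values shown sits.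
By contrast, 5-methoxy-1H-indol-2-yl in place of 5-methoxy-1-benzofuran-2-yl on a carbonyl carbon gives no change at the digits printed from compound 1 to compound 4 (within the scatter), so that exchange leaves the read-out where it was.

The compounds shown leave open what a chain ending in an amine or a carboxylic acid, or a longer chain, would do at this position. They also leave open whether benzyloxy in place of benzyl would move the number in compound 1 as well.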